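Swapping One Aromatic Ring Substituent on a Fused Amide Scaffold

The source may hold more compounds than are shown below. What is called first, only, known or untested is meant among the compounds shown, and "the series" means these compounds.

Of the compounds shown here, two have so far been measured in a functional assay on MDA-MB-231 cells (Homo sapiens) for cytotoxicity, read by MTT assay, with a stated time of 72 h; on this read-out lower numbers stand for stronger inhibition and higher numbers for weaker inhibition. Compound 1 `COc1cc(Nc2cc(Nc3ccc(Oc4ccncc4-c4cccnc4)c(F)c3)ncn2)cc(OC)c1` gives 4240 nM in this assay. Compound 2 `COc1ccc(-n2nc(C(=O)Nc3ccc(Oc4ccncc4-c4cccnc4)c(F)c3)c3ccccc3c2=O)cc1` gives 10400 nM in this assay, the higher of the two numbers; its gap from compound 1 lies beyond the usual scatter of repeated measurements, so compound 2 is the weaker inhibitor of the pair. Compound 3 `O=C(Nc1ccc(Oc2ccncc2-c2cccnc2)c(F)c1)c1nn(-c2cccc(F)c2)c(=O)c2ccccc12` has not yet been measured. It differs from compound 2 in one place: 3-fluorophenyl in place of 4-methoxyphenyl on an aromatic nitrogen. Among the compounds with values here, no pair of measured compounds differs by this change alone, so nothing measured shows how this assay responds to it. Within the data shown here, the group that leaves and the group that enters each contain one six-membered aromatic ring of carbon only, and with no guidance from measured steps, a step no larger than the scatter, in either direction, is the most plausible expectation. Compound 3 is therefore estimated to give 9000 nM in this assay, with a range from 3000 nM to 27000 nM. The step of a 1.2-fold lower number from compound 2 to compound 3 (0.06 log units; within the scatter) is expected to be small, a guess rather than a measurement.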

Compound 3, half-maximal inhibitory concentration: 72 nM
Compound 3: middle estimate off by 130-fold (2.10 log units), on the high side; the measured number lies below the stated range.
By their numbers in this assay, from the lowest: compound 3; then compound 1; then compound 2.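

In this assay, placing 3-fluorophenyl instead of 4-methoxyphenyl on the aromatic nitrogen gives a 140-fold lower number from compound 2 to compound 3 (2.16 log units; beyond the scatter), so this position can respond very strongly to a change in the group it carries. Both groups contain one six-membered aromatic ring of carbon only, which shows that a large step does not require replacing that ring: changing what the ring carries, and where, is enough here. Nothing measured in this set accounts for the size of the step.

This one exchange removes a methoxy group, adds a fluorine and alters the place of the substituent on the ring all at once, so compound 2 and compound 3 alone cannot show which of these changes carries the step. Going by these compounds, it also remains open how a plain phenyl group on the same nitrogen would compare in this assay, or how this ring would fare carrying an amine or a carboxylic acid in place of the fluorine.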